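Working notes on the shared core: compound 3 to compound 4

The source may report more compounds than this note shows. Statements on the series, on what has been measured and on what is new or still open speak of the compounds shown alone.

Compound 1 `Cc1cc(C)c(S(=O)(=O)N2CCC(N3CCC(O)CC3)CC2)c(C)c1` is measured in an ADME assay on HCT-116 cells (Homo sapiens) for cytotoxicity, read by CellTiter-Glo, with a stated time of 72 h; a higher number here means a weaker inhibitor, a lower number a stronger inhibitor. Compound 1 gives > 5000 nM, which is a limit of the assay and not a number. Compound 2 `Cc1cc(C)c(S(=O)(=O)N2CCC(N3CCC(CCO)CC3)CC2)c(C)c1` in this assay gives > 5000 nM, again only a limit. Compound 3 `Cc1cc(C)c(S(=O)(=O)N2CCC(N3CCN(C)CC3)CC2)c(C)c1` in this assay gives > 5000 nM, also a limit. Compound 3 thus stands with the other two at the limit of > 5000 nM in this assay, at which 3 of the 3 values shown sit, and none of the three values is a number. The steps a step that the two limits leave unreadable from compound 1 to compound 2, a step that the two limits leave unreadable from compound 1 to compound 3 and a step that the two limits leave unreadable from compound 2 to compound 3 are all unreadable.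

Compound 4 `Cc1cc(C)c(S(=O)(=O)N2CCC(c3ccccc3)CC2)c(C)c1` is not yet measured. It differs from compound 3 in one place: phenyl in place of 4-methylpiperazin-1-yl on a saturated ring carbon. Going by the values given here, no measured step bears on this change: every one of the three known steps is unreadable, and all three values sit at the limit. For this assay no step beyond the scatter is therefore expected, and the expected step that the limit leaves unreadable from compound 3 to compound 4 reflects this. Compound 4 is estimated at 6000 nM, with a range from 2000 nM to 50000 nM, and the assay is expected most likely to report only a limit once more.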

Compound 4, half-maximal inhibitory concentration: > 5000 nM
Compound 4: a limit, no number (the forecaster's own chance of this, stated with the estimate: 70%); the middle value lies beyond the limit too.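

Compound 4 gives only a limit, so the steps to it from compound 1, compound 2 and compound 3 cannot be read, and all four compounds stand together: the limit of > 5000 nM in this assay, at which 4 of the 4 values shown sit.

The compounds shown leave open whether any group on this saturated ring carbon of the shared core gives a readable number in this assay.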